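Working notes: from compound 3 to compound 4

The source may report more compounds than this note shows. Statements on the series, on what has been measured and on what is new or still open speak of the compounds shown alone.

Going by the values given here, in a functional assay on MDA-MB-436 cells (Homo sapiens) for antiproliferative activity, read by MTT assay, with a stated time of 48 h (on this read-out lower numbers stand for stronger inhibition and higher numbers for weaker inhibition), three compounds have measured values so far. Compound 1 (`C=CS(=O)(=O)N1CCN(c2ccn3ncc(-c4ccccc4)c3n2)CC1`) gives 19500 nM, and compound 2 (`C=CS(=O)(=O)N1CCN(c2ncnc3sc(-c4ccc(N5CCN(C)CC5)cc4)cc23)CC1`) gives 8760 nM. Compound 3 (`C=CS(=O)(=O)N1CCN(c2ncnc3sc(-c4ccnc(Cl)c4)cc23)CC1`) gives 30100 nM. That value lies within the scatter of compound 1, while the number for compound 2 is lower than that of compound 3 by more than the scatter.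

Compound 4 (`C=CS(=O)(=O)N1CCN(c2ncnc3sc(C4=CCCCC4)cc23)CC1`) has cyclohex-1-en-1-yl in place of 2-chloropyridin-4-yl on an aromatic carbon, next to the ring sulfur: cyclohex-1-en-1-yl in place of 2-chloropyridin-4-yl on an aromatic carbon.

Among the compounds with values here, no measured pair isolates a change at this place, so the expectation rests only on the spread of the three values. All three compounds are weak in this assay, and nothing shown points to a large shift. The expected change is small, a 1.7-fold lower number from compound 3 to compound 4 (0.22 log units; within the scatter), toward a lower number and within the scatter. The estimate for compound 4 is 18000 nM, with an expected range of 8000 nM to 40000 nM.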

Compound 4, half-maximal inhibitory concentration: > 50000 nM
Compound 4 gave a limit, no number; the forecaster's own chance of this, stated with the estimate: 10%; at least 2.7-fold (0.44 log units) between middle value and limit.
By their numbers in this assay, from the lowest: compound 2; then compounds 1 and 3 (each within the scatter of the next). At a limit, above all of these: compound 4.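

In this assay compound 4 gives > 50000 nM, which is a limit of the assay and not a number. Going by these compounds alone, this is the first step at the aromatic carbon next to the ring sulfur, with cyclohex-1-en-1-yl in place of 2-chloropyridin-4-yl, and it reads as an at least 1.6-fold higher number from compound 3 to compound 4 (0.22 log units; that floor lies within the scatter). The change brings no gain in this assay, and the true size of the step stays unresolved, since the reading for the cyclohex-1-en-1-yl compound ends at the limit: the limit of > 50000 nM in this assay, at which 1 of the 4 values shown sits.

Still open, as far as these compounds go, is whether a fully saturated cyclohexyl group would read any differently at this place. Also open, from the compounds shown here alone, is whether a cyclohexyl ring carrying an amine or a carboxylic acid would bring the reading back to a measurable number.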